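A few compounds are considered here, and "the series" means these few. Any claim that something is new, unique, unknown or untested is made for them only; others in the source may bear on it.

Compound 1 `COc1ccc(-c2nc(C(=O)/C=C\Nc3ccc4[nH]ccc4c3)c3ccccn23)cc1` stands at the weaker end of the pair: in a functional assay on B16-F10 cells (Mus musculus) for cytotoxicity, read by MTT assay, with a stated time of 48 h (on this read-out lower numbers stand for stronger inhibition and higher numbers for weaker inhibition), compound 1 gives 5120 nM, while compound 2 `COc1ccc(N/C=C\C(=O)c2nc(-c3ccc(OC)cc3)n3ccccc23)cc1` gives 2120 nM. For the measured compounds named here, the single measured step, a 2.4-fold lower number from compound 1 to compound 2 (0.38 log units; beyond the scatter), alters the aryl on the amine nitrogen. Going by the values given here, compound 3 `O=C(/C=C\Nc1ccc2[nH]ccc2c1)c1nc(-c2ccc(C(F)(F)F)cc2)n2ccccc12` instead carries trifluoromethyl in place of methoxy on an aromatic carbon, a change at a different place on the shared core, so no measured step bears on it. Lacking a comparable step, the expected outcome for compound 3 is a 1.0-fold lower number from compound 1 to compound 3 (0.01 log units; within the scatter), nothing beyond the scatter. Compound 3 is therefore estimated at 5000 nM, with a range of 2000 nM to 12500 nM.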

Compound 3, half-maximal inhibitory concentration: 18200 nM
The estimate for compound 3 lay 3.6-fold (0.56 log units) below the measured number, outside the stated range (above it).
By their numbers in this assay, from the lowest: compound 2; then compound 1; then compound 3.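

Replacing methoxy with trifluoromethyl on this aromatic carbon, para to a large group, is not neutral in this assay: the change gives a 3.6-fold higher number from compound 1 to compound 3 (0.55 log units; beyond the scatter), with the indol-5-yl amine held constant. For the compounds shown here, the earlier pair varied only the aryl on the amine nitrogen, so this is the first indication that the 4-methoxyphenyl end of the series also moves the number. No measurement is available to explain the shift. Still open, as far as these compounds go, is whether a hydroxyl, an amine or a plain hydrogen at this position would keep the value of compound 1. Also open, from the compounds shown here alone, is whether the same change would have a similar effect on compound 2.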